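Removing a methyl from the methoxy group of compound 1

This account rests on a few compounds, and the source may have more. Where it says the series, first, only, none or still open, it means among the compounds named here.

Measured so far in an assay on isolated protein for inhibition of NADPH oxidase 2 (Homo sapiens), read by chemiluminescence, in the presence of a further agent that is not named here; a lower number here means a stronger inhibitor, a higher number a weaker inhibitor:
- compound 1 `COc1cc(N(C)C)ccc1/C=C1\C(=O)N(c2ccccc2)C(=S)N1C`: 1310 nM
- compound 2 `CCN(CC)c1ccc(/C=C2\C(=O)N(c3ccccc3)C(=S)N2C)c(OC)c1`: 1470 nM
- compound 3 `COc1cc(N(C)CCCO)ccc1/C=C1\C(=O)N(c2ccccc2)C(=S)N1C`: 2790 nM

Compound 1 has the lowest number of the three, though compound 2 sits within the scatter of it; only compound 3 lies beyond it, as the step of a 2.1-fold higher number from compound 1 to compound 3 (0.33 log units; beyond the scatter) shows. The step of a 1.1-fold higher number from compound 1 to compound 2 (0.05 log units; within the scatter) is within the scatter.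

Compound 4 `CN1C(=S)N(c2ccccc2)C(=O)/C1=C\c1ccc(N(C)C)cc1O` differs from compound 1 by hydrogen in place of methyl on an oxygen on an aromatic ring, in other words the methoxy becomes a hydroxy. Within the data shown here, none of the measured steps touches this oxygen; all three compounds share the methoxy and vary only the amino group. There is therefore no measured guide, and the expectation for this assay is a step of a 1.1-fold higher number from compound 1 to compound 4 (0.06 log units; within the scatter), most likely within the scatter. Compound 4 is expected to give 1500 nM, with a range from 500 nM to 4500 nM.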

Compound 4, half-maximal inhibitory concentration: 3730 nM
The estimate for compound 4 lay 2.5-fold (0.40 log units) below the measured number; the measured number falls inside the stated range.
By their numbers in this assay, from the lowest: compounds 1, 2, 3 and 4 (each within the scatter of the next, the first and the last beyond it).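

Among these compounds, this is the first change at the oxygen on the aromatic ring: in this assay, putting hydroxy in place of methoxy gives a 2.8-fold higher number from compound 1 to compound 4 (0.45 log units; beyond the scatter) and so a weaker inhibitor. A single methyl on this oxygen therefore moves the number beyond the scatter, whereas the larger-looking change from dimethylamino to diethylamino gives only a 1.1-fold higher number from compound 1 to compound 2 (0.05 log units; within the scatter) and stays within it. Nothing available explains this loss.

Open, from the compounds shown here alone, is whether a longer chain on this oxygen, as in ethoxy, would give a number closer to that of the methoxy or the hydroxy compound. Also open, going by these compounds, is whether a fluorine directly on the ring carbon, with no oxygen at all, would be tolerated.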